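From compound 1 to compound 4: one aromatic group exchanged

The compounds below may be only part of what the source reports. "The series", "measured", "known", "first", "only" and "open" are said of these compounds alone.

In a functional assay on DU-145 cells (Homo sapiens) for inhibition, read by trypan blue exclusion, with a stated time of 96 h (on this read-out lower numbers stand for stronger inhibition of growth and higher numbers for weaker inhibition of growth), compound 1 (`CSc1ccc(/C=C(\C(=O)c2ccc(Br)cc2)S(=O)(=O)Cc2ccc(F)cc2)cc1`) gives 50000 nM as its read-out. Compound 3 (`O=C(/C(=C\c1c[nH]c2ccccc12)S(=O)(=O)Cc1ccc(F)cc1)c1ccc(Cl)cc1`) gives 50000 nM and so stands level with compound 1 within the scatter. Compound 2 (`COc1cc(OC)c(/C=C(/C(=O)c2ccc(Cl)cc2)S(=O)(=O)Cc2ccccc2Cl)c(OC)c1`) is reported as > 100000 nM and that figure is a limit of the assay, not a number. Compound 1 therefore sits at the only numeric level shown in this small set.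

Compound 4 (`Cc1cc(C)cc(/C=C(\C(=O)c2ccc(Br)cc2)S(=O)(=O)Cc2ccc(F)cc2)c1`), not yet measured, has 3,5-dimethylphenyl in place of 4-(methylsulfanyl)phenyl on a double-bonded chain carbon bound to a double-bonded chain carbon. Going by the values given here, no measured pair isolates this exchange, so no shift beyond the scatter is expected in this assay in either direction. The expectation rests on compound 1 at 50000 nM as the starting point, and the step itself is expected to stay small (estimated: a 1.3-fold lower number from compound 1 to compound 4 (0.10 log units; within the scatter)). Compound 4 is estimated at 40000 nM with an expected range from 10000 nM to 100000 nM on this read-out.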

Compound 4, concentration for 50% growth inhibition: 10000 nM
The estimate for compound 4 lay 4.0-fold (0.60 log units) above the measured number; low and high end bracket the measured number.
By their numbers in this assay, from the lowest: compound 4; then compounds 1 and 3 (each within the scatter of the next). At a limit, above all of these: compound 2.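

The exchange of 4-(methylsulfanyl)phenyl for 3,5-dimethylphenyl gives a 5.0-fold lower number from compound 1 to compound 4 (0.70 log units; beyond the scatter) in this assay and is the only single-place step shown in the series. The position on a double-bonded chain carbon bound to a double-bonded chain carbon therefore responds to the aromatic group it carries, even though both groups hold 8 heavy atoms and one six-membered aromatic ring of carbon only. No measured property shown here bears on this step, so it stands without an assigned cause.

From the compounds shown here alone, whether the direction of the step holds for other groups at this position, such as an aromatic ring carrying an amine or a carboxylic acid, remains open. Also open, going by these compounds, is whether the same exchange gives a similar step when the other aromatic groups on the core are different.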